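The source may hold more compounds than are shown below. What is called first, only, known or untested is meant among the compounds shown, and "the series" means these compounds.

In an ADME assay on Caco-2 cells (Homo sapiens) for permeability (a higher number here means that the compound crosses the layer faster, a lower number that the compound crosses the layer more slowly), compound 1 (`CC(C)Oc1cc(-c2cncc(-c3cnn(C4COC4)c3)c2)ccc1C(N)=O`) gives 25 10^-6 cm/s, within the scatter of both compound 2 (`Cc1[nH]ncc1-c1cncc(-c2ccc(C(N)=O)c(OC(C)C)c2)c1`) at 33 10^-6 cm/s and compound 3 (`Cc1c(-c2cncc(-c3ccc(C(N)=O)c(OC(C)C)c3)c2)cnn1C`) at 21 10^-6 cm/s. Compound 4 (`CC(C)Oc1cc(-c2cccnc2)ccc1C(N)=O`) differs from compound 1 as follows: hydrogen in place of 1-(oxetan-3-yl)-1H-pyrazol-4-yl on an aromatic carbon. Two measured steps replace the same 1-(oxetan-3-yl)-1H-pyrazol-4-yl group with another pyrazolyl group: a 1.3-fold higher number from compound 1 to compound 2 (0.12 log units; within the scatter) and a 1.2-fold lower number from compound 1 to compound 3 (0.08 log units; within the scatter). A third, a 1.6-fold lower number from compound 2 to compound 3 (0.20 log units; within the scatter), places methyl on an aromatic nitrogen. All three stay within the scatter. None of them removes the group and leaves hydrogen, so the evidence is indirect. The step expected in this assay is a 1.2-fold higher number from compound 1 to compound 4 (0.08 log units; within the scatter), none beyond the scatter. The estimated value for compound 4 is 30 10^-6 cm/s, with an expected range of 15 10^-6 cm/s to 55 10^-6 cm/s.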

Compound 4, apparent permeability: 20 10^-6 cm/s
Beside the measured number, compound 4's estimate is 1.5-fold (0.18 log units) above it, and the stated range covers the measured number.
By their numbers in this assay, from the lowest: compounds 4, 3, 1 and 2 (each within the scatter of the next).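

Taking the group off entirely and leaving hydrogen on this aromatic carbon gives three direct readings in this assay, all within the scatter: a 1.3-fold lower number from compound 1 to compound 4 (0.10 log units; within the scatter) and a 1.1-fold lower number from compound 3 to compound 4 (0.02 log units; within the scatter) and a 1.7-fold lower number from compound 2 to compound 4 (0.22 log units; within the scatter). Across compounds 1, 2, 3 and 4, this read-out therefore does not separate hydrogen from any of the three pyrazolyl groups, a comparison the pyrazolyl-for-pyrazolyl steps could not give. No measurement here offers an explanation for this result.

As far as these compounds go, whether a carboxylic acid or a primary amine on this aromatic carbon would step beyond the scatter remains open.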